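The source may hold more compounds than are shown below. What is called first, only, known or untested is meant among the compounds shown, and "the series" means these compounds.

Measured compounds:
- compound 1, `CCC(CC)n1c(-c2ccc(OCc3c(-c4c(Cl)cccc4Cl)noc3C(C)C)cc2)nc2ccc(C(=O)O)cc21` — 0.8 nM
- compound 2, `CC(C)c1onc(-c2c(Cl)cccc2Cl)c1COc1ccc(-c2nc3ccc(C(=O)O)cc3n2Cc2ccc(F)cc2)cc1` — 3.31 nM
- compound 3, `CCn1c(-c2ccc(OCc3c(-c4c(Cl)cccc4Cl)noc3C(C)C)cc2)nc2ccc(C(=O)O)cc21` — 2.31 nM

All three were read in an assay on Huh-7 cells for agonist activity at Bile acid receptor (Homo sapiens), read by a luciferase reporter; on this read-out higher numbers stand for an effect only at larger amounts of compound and lower numbers for an effect already at smaller amounts. Compound 1 gives the lowest of the three numbers in this assay; the nearest is compound 3, the furthest compound 2, and both gaps lie beyond the scatter. The series varies only the group on the aromatic nitrogen of the shared core.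

The next compound is compound 4, `CCCn1c(-c2ccc(OCc3c(-c4c(Cl)cccc4Cl)noc3C(C)C)cc2)nc2ccc(C(=O)O)cc21`, not yet measured. Relative to compound 1 the change is hydrogen in place of ethyl on a saturated chain carbon bound to an aromatic nitrogen and a saturated chain carbon, so the branched pentan-3-yl chain is shortened to a straight propyl chain.

Among the compounds with values here, two measured steps bear on this. Trimming the same group to ethyl gave a 2.9-fold higher number from compound 1 to compound 3 (0.46 log units; beyond the scatter). Exchanging it for 4-fluorobenzyl gave a 4.1-fold higher number from compound 1 to compound 2 (0.62 log units; beyond the scatter). Within the data shown here, compound 4 keeps more of the chain than compound 3 does, so a step smaller than the one to compound 3 is expected, in the same direction, and it may stay within the scatter. The expected step for compound 4 is a 1.8-fold higher number from compound 1 to compound 4 (0.24 log units; within the scatter). For compound 4 in this assay the estimate is 1.4 nM, with a range from 0.6 nM to 3.5 nM.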

Compound 4, half-maximal effective concentration: 9.3 nM
Estimate against measurement, compound 4: 6.6-fold (0.82 log units) below; measured number outside the range, above it.
By their numbers in this assay, from the lowest: compound 1; then compounds 3 and 2 (each within the scatter of the next); then compound 4.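

In this assay, within the data shown here, the group on the aromatic nitrogen does not act as a simple length series: pentan-3-yl to propyl gives a 12-fold higher number from compound 1 to compound 4 (1.07 log units; beyond the scatter), so removing an ethyl from the branched chain costs far more than the earlier steps suggested. Adding a single methyl to the ethyl group of compound 3 also moves the number the unfavourable way, with a 4.0-fold higher number from compound 3 to compound 4 (0.60 log units; beyond the scatter), so the straight chains do not improve as they lengthen, and the order runs ethyl, then propyl, with branched pentan-3-yl lowest of all. Replacing the 4-fluorobenzyl of compound 2 with the propyl chain's ethyl end gives a 2.8-fold higher number from compound 2 to compound 4 (0.45 log units; beyond the scatter), which places propyl behind even this aromatic group, and no measurement shown accounts for any of this.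

As far as these compounds go, whether the low number of compound 1 depends on branching at the carbon bound to the aromatic nitrogen, or on the overall size of the group, stays open, and isopropyl, butyl and cyclopentyl on that nitrogen would separate the two. A longer straight chain such as pentyl would show whether propyl is an isolated high point or the start of a trend.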